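The compounds below may be only part of what the source reports. "The series", "measured", "known", "first", "only" and "open" are said of these compounds alone.

For the measured compounds named here, in a functional assay on K562 cells (Homo sapiens) for inhibition (on this read-out higher numbers stand for weaker inhibition and lower numbers for stronger inhibition), compound 1 (`Cc1ccc(Cl)cc1-c1cc(Nc2ccc(Br)cc2)nc(N)n1`) gives 60 nM and compound 2 (`Cc1ccc(Br)cc1-c1cc(Nc2ccc(Cl)cc2)nc(N)n1`) gives 70 nM, so compound 2 stands within the scatter of the only other measured compound. Compound 3 (`Cc1ccc(Br)cc1-c1cc(Nc2ccc(Br)cc2)nc(N)n1`) has not yet been measured. It differs from compound 2 by bromo in place of chloro on an aromatic carbon, para to a large group, which turns 4-chlorophenyl into 4-bromophenyl. The two measured compounds differ in more than one place, so the data offer no direct measure of this exchange. Still, compound 1 carries the same 4-bromophenyl group and gives 60 nM in this assay, so no shift beyond the scatter is expected. The estimated step of a 1.2-fold lower number from compound 2 to compound 3 (0.07 log units; within the scatter) is therefore expected to be small. For compound 3 the estimated value is 60 nM, with an expected range of 25 nM to 150 nM.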

Compound 3, half-maximal inhibitory concentration: 70 nM
Compound 3: middle estimate off by 1.2-fold (0.07 log units), on the low side; the measured number falls inside the stated range.
By their numbers in this assay, from the lowest: compounds 1, 2 and 3 (each within the scatter of the next).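

In this assay, bromo in place of chloro on the 4-chlorophenyl group, on an aromatic carbon para to a large group, gives no change at the digits printed from compound 2 to compound 3 (within the scatter), so at this position the two halogens cannot be told apart. The same exchange at the other halogen of the series gives a 1.2-fold higher number from compound 1 to compound 3 (0.07 log units; within the scatter), which means that both single exchanges now have a direct measure and both stay within the scatter. No other data on these compounds bear on why the numbers stay together. All three compounds carry only chloro or bromo at these places, so the result says nothing about how far this tolerance extends. On these data alone, whether hydrogen, a methoxy group, an amine or a carboxylic acid at the same position would hold the number in this assay remains open.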